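The compounds below may be only part of what the source reports. "The series", "measured", "known", "first", "only" and "open" are said of these compounds alone.

Compound 1 `COc1ccc(-c2cccc(=O)n2-c2cc(OC)c(OC)c(OC)c2)cc1O` gives < 10 nM in a functional assay on SK-OV-3 cells (Homo sapiens) for cytotoxicity, read by spectrophotometry, with a stated time of 72 h (on this read-out higher numbers stand for weaker inhibition and lower numbers for stronger inhibition), which is a limit of the assay rather than a number (the limit of < 10 nM in this assay, at which 1 of the 3 values shown sits). Compound 2 `COc1cc(-n2c(-c3cccc(O)c3)cccc2=O)cc(OC)c1OC` gives 1460 nM in this assay. The change between them, (methoxy in place of hydrogen on an aromatic carbon), made an at least 140-fold lower number from compound 2 to compound 1 (2.16 log units; beyond the scatter). Compound 3 `COc1ccc(-n2c(-c3cc(OC)c(OC)c(OC)c3)cccc2=O)cc1` gives 1540 nM in this assay; the difference between the cores of compound 2 and compound 3 is not broken down here, and the two values lie within the scatter of each other. Compound 4 `COc1ccc(-n2c(-c3cc(OC)c(OC)c(OC)c3)cccc2=O)cc1OC` has not yet been measured. It differs from compound 3 by methoxy in place of hydrogen on an aromatic carbon, the same kind of change as from compound 2 to compound 1, but around a place ortho to a methoxy group and meta to a large group instead of ortho to a hydroxy group and para to a large group. Among the measured compounds shown here, compound 4 is expected to show a 10-fold lower number from compound 3 to compound 4 (1.01 log units; beyond the scatter) in this assay, a step resting on the single measured pair an at least 140-fold lower number from compound 2 to compound 1 (2.16 log units; beyond the scatter) yet set smaller for the changed surroundings. Compound 4 is estimated at 150 nM, between 20 nM and 1000 nM.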

Compound 4, half-maximal inhibitory concentration: 14300 nM
The estimate for compound 4 lay 95-fold (1.98 log units) below the measured number, outside the stated range (above it).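

In this assay, methoxy in place of hydrogen on an aromatic carbon gave a 9.3-fold higher number from compound 3 to compound 4 (0.97 log units; beyond the scatter), so the change did not carry from one core to the other with the same direction: the same change on two cores in this assay, an at least 140-fold lower number (2.16 log units; beyond the scatter) from compound 2 to compound 1 and a 9.3-fold higher number (0.97 log units; beyond the scatter) from compound 3 to compound 4, at least 1300-fold (3.13 log units) apart, beyond the scatter of two such steps

Compound 1 stands at a limit of the assay rather than a number: the limit of < 10 nM in this assay, at which 1 of the 4 values shown sits.

These two pairs show that the outcome of this change depends on its surroundings in this series, but they do not show which difference between the cores or the places is responsible, nor how the change would read on any further core.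

Still open, as far as these compounds go, is how an ethoxy group, a fluorine atom or an amine would read on the aromatic carbon that carries the new methoxy in compound 4. Also open, from the compounds shown here alone, is whether such a group would follow compound 4 or compound 1 in direction.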